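A few compounds are considered here, and "the series" means these few. Any claim that something is new, unique, unknown or untested is made for them only; others in the source may bear on it.

Measured compounds:
compound 1, `C=CCc1cc(C(C)=O)c(O)cc1OCCCCCC#N`, giving 81%
compound 2, `CCc1cc(C(C)=O)c(O)cc1OCCCCCC(C)(C)C(=O)O`, giving 104%

Both numbers come from an assay on isolated protein for inhibition of leukotriene B4 receptor 1 (Homo sapiens), tested at 10 uM; on this read-out higher numbers stand for more inhibition at the one concentration tested (going by the name of the read-out) and lower numbers for less inhibition. Compound 1 stands lowest of the two, and its nearest neighbour, compound 2, sits a number higher than compound 1 by a margin beyond the scatter. For the measured compounds named here, no pair of measured compounds differs in a single place, so no measured step is available to guide what follows.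

The unmeasured compound 3, `C=CCCCCOc1cc(O)c(C(C)=O)cc1CC=C`, is reached from compound 1 by one change: vinyl in place of cyanomethyl on a saturated chain carbon, four bonds along the chain from an oxygen on an aromatic ring. Since only the value of compound 1 anchors this change, the expectation is cautious: a step from compound 1 to compound 3 in this assay that is expected to be small, likely a slight drop, and not clearly beyond the scatter, a number 6 percentage points lower from compound 1 to compound 3 (within the scatter). Compound 3 is therefore expected to give about 75%, in a range from 50% to 95%.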

Compound 3, a percentage reported as inhibition, at one concentration (the size of the read-out at that concentration, not a potency): 73%
Compound 3: the middle estimate sits 2 percentage points above what was measured; low and high end bracket the measured number.
By their numbers in this assay, from the lowest: compounds 3 and 1 (each within the scatter of the next); then compound 2.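

Replacing cyanomethyl with vinyl on a saturated chain carbon, four bonds along the chain from an oxygen on an aromatic ring, gives in this assay a step of a number 8 percentage points lower from compound 1 to compound 3 (within the scatter). For the compounds shown here, this is the first single-place step, and it shows that the chain end can go from a nitrile to an alkene, losing the hydrogen-bond acceptor counted on cyanomethyl, without a shift beyond the scatter in this read-out. Nothing available explains this outcome.

The compounds shown leave open whether an amine or a hydroxyl group in place of cyanomethyl at this position would produce a step beyond the scatter. They also leave open whether a longer chain carrying the nitrile would do so.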